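From 4-(Trifluoromethyl)phenyl to 4-Fluorobenzyl on a Ring Nitrogen

This account rests on a few compounds, and the source may have more. Where it says the series, first, only, none or still open, it means among the compounds named here.

Of the compounds shown here, three sharing one core have been tested in a functional assay on Mahlavu cells (Homo sapiens) for antiproliferative activity, read by sulforhodamine B assay, with a stated time of 72 h; on this read-out higher numbers stand for weaker inhibition and lower numbers for stronger inhibition. Compound 1 `N#Cc1ccccc1COc1ccc(-c2cc(CN3CCN(Cc4ccc(C(F)(F)F)cc4)CC3)no2)cc1` gives 3500 nM, compound 2 `Fc1ccccc1COc1ccc(-c2cc(CN3CCN(Cc4ccc(C(F)(F)F)cc4)CC3)no2)cc1` gives 3100 nM, and compound 3 `N#Cc1cccc(COc2ccc(-c3cc(CN4CCN(c5ccc(C(F)(F)F)cc5)CC4)no3)cc2)c1` gives 2700 nM. Within the data shown here, the only single change among them, a 1.1-fold lower number from compound 1 to compound 2 (0.05 log units; within the scatter), alters a part of the molecule other than the one considered here. Compound 3 sits within the usual scatter of both compound 1 and compound 2, so the three read as essentially one level.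

Compound 4 `N#Cc1cccc(COc2ccc(-c3cc(CN4CCN(Cc5ccc(F)cc5)CC4)no3)cc2)c1` has not yet been measured. It differs from compound 3 by 4-fluorobenzyl in place of 4-(trifluoromethyl)phenyl on an amine nitrogen in a ring. No measured step touches this ring nitrogen, so nothing shown speaks directly to the change; what is shown is that a modest alteration elsewhere on the core left the read-out flat. The expected step is a 1.1-fold higher number from compound 3 to compound 4 (0.05 log units; within the scatter), meaning no movement beyond the scatter. For compound 4 the estimate in this assay is 3000 nM, with a range from 1200 nM to 7500 nM.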

Compound 4, half-maximal inhibitory concentration: 1500 nM
For compound 4 the middle estimate is 2.0-fold (0.30 log units) above the measured one; measured number inside the range.
By their numbers in this assay, from the lowest: compounds 4, 3, 2 and 1 (each within the scatter of the next, the first and the last beyond it).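

Across this assay this is the first measured step at this ring nitrogen, and 4-fluorobenzyl in place of 4-(trifluoromethyl)phenyl gives a 1.8-fold lower number from compound 3 to compound 4 (0.26 log units; within the scatter) within the usual scatter. The nitrogen therefore tolerates this exchange of one aromatic substituent for another without a change that can be told from repeat-measurement noise. The swap alters the link to the ring and the group on it together, from phenyl to benzyl and from trifluoromethyl to fluorine, and no measurement available here bears on the result.

The compounds shown leave open how much each of those two alterations contributes. They also leave open whether a group without an aromatic ring, such as a methyl, a longer alkyl chain or an acetyl, would keep the read-out at this level.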